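From 4-methoxyphenyl to 6-methoxypyridin-3-yl

This account rests on a few compounds, and the source may have more. Where it says the series, first, only, none or still open, it means among the compounds named here.

Compound 1 `C=CS(=O)(=O)N1CCN(c2ccn3ncc(-c4ccccc4)c3n2)CC1`: 38300 nM
Compound 2 `C=CS(=O)(=O)N1CCN(c2ncnc3sc(-c4ccc(OC)cc4)cc23)CC1`: 29900 nM
Compound 3 `C=CS(=O)(=O)N1CCN(c2ncnc3sc(-c4cn(S(=O)(=O)c5ccccc5)c5ccccc45)cc23)CC1`: 40400 nM

In a functional assay on MDA-MB-231 cells (Homo sapiens) for antiproliferative activity, read by MTT assay, with a stated time of 48 h (on this read-out lower numbers stand for stronger inhibition and higher numbers for weaker inhibition), compound 2 gives 29900 nM, within the usual scatter of both other compounds, so the three cannot be ranked. Compound 4 `C=CS(=O)(=O)N1CCN(c2ncnc3sc(-c4ccc(OC)nc4)cc23)CC1` carries 6-methoxypyridin-3-yl in place of 4-methoxyphenyl on an aromatic carbon, next to the ring sulfur: 6-methoxypyridin-3-yl in place of 4-methoxyphenyl on an aromatic carbon. Among the measured compounds shown here, no measured pair isolates a single change, so no direct guide to this swap exists. Even with a much larger group than compound 2 has, compound 3 gives 40400 nM, within the scatter of compound 2 at 29900 nM. No step beyond the scatter is therefore expected in this assay. The expected change is a 1.1-fold higher number from compound 2 to compound 4 (0.03 log units; within the scatter). For compound 4 the estimated value is 32000 nM, with an expected range of 15000 nM to 60000 nM.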

Compound 4, half-maximal inhibitory concentration: 9270 nM
Beside the measured number, compound 4's estimate is 3.5-fold (0.54 log units) above it, outside the stated range (below it).
By their numbers in this assay, from the lowest: compound 4; then compounds 2, 1 and 3 (each within the scatter of the next).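

In this assay, among the compounds shown here, 6-methoxypyridin-3-yl in place of 4-methoxyphenyl gives a 3.2-fold lower number from compound 2 to compound 4 (0.51 log units; beyond the scatter), the only step that can be read here. This place on the shared core therefore responds to a swap that keeps the heavy-atom count and exchanges one ring carbon for nitrogen, adding a hydrogen-bond acceptor. Nothing available explains the shift. Going by these compounds, it remains open whether an amine or an ethoxy group in place of the methoxy on the same ring would keep this lower number.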